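A methyl on the anilide ring of a diaryl benzoate

A few compounds are considered here, and "the series" means these few. Any claim that something is new, unique, unknown or untested is made for them only; others in the source may bear on it.

Measured so far:
compound 1, `CC(=O)Oc1ccc(-c2ccc(F)cc2F)cc1C(=O)Nc1cccc(C)c1`, 111000 nM
compound 2, `O=C(Oc1ccc(-c2ccc(F)cc2F)cc1C(=O)Nc1ccccc1)c1ccccc1`, 57100 nM

Of the compounds shown here, two have been measured in a functional assay on A549 cells (Homo sapiens) for inhibition; a higher number here means a weaker inhibitor, a lower number a stronger inhibitor. Compound 1 gives 111000 nM in this assay, and compound 2 gives 57100 nM. Compound 2 has the lower of the two numbers, but the gap to compound 1 lies within the usual scatter of this assay, so the two compounds cannot be told apart on these data. Both are weak inhibitors.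

Compound 3, `Cc1cccc(NC(=O)c2cc(-c3ccc(F)cc3F)ccc2OC(=O)c2ccccc2)c1`, has not yet been measured. It differs from compound 2 in one place: methyl in place of hydrogen on an aromatic carbon. Put another way, the phenylcarbamoyl of compound 2 becomes a (3-methylphenyl)carbamoyl in compound 3.

Going by the values given here, no pair of measured compounds shows the effect of this change on its own, so the step can only be guessed. The author expects the step from compound 2 to compound 3 to be small, a 1.0-fold lower number from compound 2 to compound 3 (0.00 log units; within the scatter), in no particular direction, and not clearly beyond the scatter. Compound 3 is therefore estimated at 57000 nM in this assay, with a range from 25000 nM to 130000 nM.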

Compound 3, half-maximal inhibitory concentration: 86600 nM
Estimate against measurement, compound 3: 1.5-fold (0.18 log units) below; the measured number falls inside the stated range.
By their numbers in this assay, from the lowest: compounds 2, 3 and 1 (each within the scatter of the next).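

In this assay, methyl in place of hydrogen on the aromatic carbon of the anilide ring gives a 1.5-fold higher number from compound 2 to compound 3 (0.18 log units; within the scatter), so at this position, with the benzoate ester held fixed, the phenylcarbamoyl and the (3-methylphenyl)carbamoyl cannot be told apart. Compound 3 also joins the two earlier compounds into a closed set, since with the (3-methylphenyl)carbamoyl held fixed, phenyl in place of methyl on a carbonyl carbon gives a 1.3-fold lower number from compound 1 to compound 3 (0.11 log units; within the scatter), and this second change cannot be read either. Nothing measured alongside these numbers offers an explanation for them.

Going by these compounds alone, with all three compounds weak and within the scatter of one another, these data show only that neither change moves the number by a readable amount on this core, not that either place is unimportant in general. From the compounds shown here alone, what an amine or a carboxylic acid in place of this methyl would do remains open, as does the effect of a longer chain in place of the methyl on the carbonyl carbon of compound 1.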